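The source may hold more compounds than are shown below. What is called first, only, known or untested is meant among the compounds shown, and "the series" means these compounds.

Measured in an assay on isolated protein for binding affinity to Leucine-rich repeat serine/threonine-protein kinase 2 variant G2019S (Homo sapiens), read by TR-FRET and LanthaScreen, with a stated time of 2 h; on this read-out higher numbers stand for weaker inhibition and lower numbers for stronger inhibition:
compound 1 `Cc1c(Nc2nc(N)c3c(C#N)c(N4CCC[C@H]4C)n(C)c3n2)cnn1C`: 3 nM
compound 2 `C[C@@H]1CCCN1c1c(C#N)c2c(N)nc(Nc3cn[nH]c3)nc2n1C`: 0.4 nM
compound 3 `Cn1c(N2CCCC2)c(C#N)c2c(N)ncnc21`: 125 nM

Compound 3 holds the highest number of the three in this assay, beyond the scatter from both compound 1 and compound 2. Within the data shown here, the only measured step, a 7.5-fold lower number from compound 1 to compound 2 (0.88 log units; beyond the scatter), concerns a substituent on a nitrogen and says nothing about the aromatic carbon changed here. Compound 4 `Cn1c(N)c(C#N)c2c(N)ncnc21` differs from compound 3 by amino in place of pyrrolidin-1-yl on an aromatic carbon. Among the measured compounds shown here, no measured pair covers this change; every measured compound carries the pyrrolidin-1-yl group, so the expectation is uncertain. The step in this assay from removing the ring is estimated as an 8.0-fold higher number from compound 3 to compound 4 (0.90 log units; beyond the scatter), towards a higher number. For compound 4 the expected value in this assay is 1000 nM, with a range from 200 nM to 5000 nM.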

Compound 4, inhibition constant: 589 nM
For compound 4 the middle estimate is 1.7-fold (0.23 log units) above the measured one; measured number inside the range.
By their numbers in this assay, from the lowest: compound 2; then compound 1; then compound 3; then compound 4.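

Amino in place of pyrrolidin-1-yl on this aromatic carbon gives, in this assay, a 4.7-fold higher number from compound 3 to compound 4 (0.67 log units; beyond the scatter), the first reading at this position. The ring is therefore not required for a measurable number here: compound 4, which lacks it, gives 589 nM. Nothing available accounts for the size of this step.

Open, as far as these compounds go, is where an open-chain amine such as dimethylamino or a morpholine ring would fall at this carbon. Also open, from the compounds shown here alone, is whether the step holds on the pyrazole-bearing cores of compound 1 and compound 2.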